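A few compounds are considered here, and "the series" means these few. Any claim that something is new, unique, unknown or untested is made for them only; others in the source may bear on it.

In a functional assay on HCT-116 cells (Homo sapiens) for cytotoxicity, read by MTT assay, with a stated time of 72 h (a higher number here means a weaker inhibitor, a lower number a stronger inhibitor), compound 1 `CN1CCN(CCCn2c3c(c4ccccc42)C(=O)c2c[n+]([O-])c4ccccc4c2C3=O)CC1` gives 560 nM and compound 2 `CN(C)CCCCn1c2c(c3ccccc31)C(=O)c1c[n+]([O-])c3ccccc3c1C2=O` gives 450 nM, so compound 2 stands level with compound 1. Compound 3 `O=C1c2c[n+]([O-])c3ccccc3c2C(=O)c2c1c1ccccc1n2Cc1cn(C[C@@H](O)CO)nn1` differs from compound 2 as follows: 1-(2,3-dihydroxypropyl)-1H-1,2,3-triazol-4-yl in place of 3-(dimethylamino)propyl on a saturated chain carbon bound to an aromatic nitrogen. This places 1-(2,3-dihydroxypropyl)-1H-1,2,3-triazol-4-yl in place of 3-(dimethylamino)propyl on a saturated chain carbon bound to an aromatic nitrogen. Among the compounds with values here, the only measured step, a 1.2-fold lower number from compound 1 to compound 2 (0.09 log units; within the scatter), exchanges 4-methylpiperazin-1-yl for (dimethylamino)methyl and includes no triazole, so it offers only weak guidance. A modest move towards weaker inhibition is expected, estimated as a 2.7-fold higher number from compound 2 to compound 3 (0.43 log units; beyond the scatter). Compound 3 is expected at 1200 nM, with an estimated range of 300 nM to 5000 nM.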

Compound 3, half-maximal inhibitory concentration: 190 nM
Compound 3: the middle estimate sits 6.3-fold (0.80 log units) above what was measured, and the stated range ends above it.
By their numbers in this assay, from the lowest: compound 3; then compounds 2 and 1 (each within the scatter of the next).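

At the saturated chain carbon bound to an aromatic nitrogen, a side chain ending in 1-(2,3-dihydroxypropyl)-1H-1,2,3-triazol-4-yl, with no amine, is tolerated in this assay: the steps read a 2.4-fold lower number from compound 2 to compound 3 (0.37 log units; beyond the scatter) and a 2.9-fold lower number from compound 1 to compound 3 (0.47 log units; beyond the scatter). Compound 1 and compound 2 differ only by an exchange of one amine for another, within the scatter, whereas these two steps lie beyond it. Nothing available explains the lower number.

Whether the triazole or the dihydroxypropyl group accounts for the steps remains open. A triazole carrying a plain propyl chain or a carboxylic acid would separate the two, and the opposite stereoisomer would test the defined stereocentre.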